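Removing the Methyl from Compound 1: an Expected Outcome

The source may report more compounds than this note shows. Statements on the series, on what has been measured and on what is new or still open speak of the compounds shown alone.

Compound 1 `CC(c1nccs1)C(C#N)(C#N)CCC(F)=C(F)F` is one of three compounds examined in a functional assay on SH-SY5Y cells (Homo sapiens) for cytotoxicity, read by MTT assay, with a stated time of 48 h; on this read-out lower numbers stand for stronger inhibition and higher numbers for weaker inhibition. For compound 1 the read-out is a limit of the assay rather than a number, > 120000 nM. Compound 3 `FC(F)=C(F)CCSc1nccs1` likewise returns only a limit in this assay, > 120000 nM. Within the data shown here, compound 2 `[O-][S+](CCC(F)(Cl)C(F)(F)Cl)c1nc2ccccc2s1` is the only one with a measured number, giving 41500 nM in this assay. Compound 1 thus stands at the limit where two of the three values sit, (the limit of > 120000 nM in this assay, at which 2 of the 3 values shown sit); between compound 1 and compound 3 the values show only that both lie at that limit, while compound 2 shows a number that falls beneath the limit of compound 1.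

Compound 4 `N#CC(C#N)(CCC(F)=C(F)F)Cc1nccs1` differs from compound 1 in one place: hydrogen in place of methyl on a saturated chain carbon bound to an aromatic carbon and a saturated chain carbon. Among the measured compounds shown here, no pair of measured compounds that differ in a single place is available, so the size of such a step has no measured precedent here. With nothing to suggest otherwise, the expected step is none beyond the scatter: a step that the limit leaves unreadable from compound 1 to compound 4. Compound 4 is accordingly expected to give about 130000 nM in this assay, within a range from 55000 nM to 300000 nM, and is expected most likely to return again only a limit.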

Compound 4, half-maximal inhibitory concentration: > 120000 nM
Compound 4 ended at the assay's limit (the forecaster's own chance of this, stated with the estimate: 70%); the middle value does not contradict the limit.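

In this assay compound 1 and compound 4 both return only a limit, so no step can be read between them. What the compounds shown leave open is whether hydrogen in place of methyl on that saturated chain carbon changes the read-out at all, with most of the values shown resting at one point: the limit of > 120000 nM in this assay, at which 3 of the 4 values shown sit.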